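Removing the Methoxy Group from the Side Chain of Compound 2

The compounds below may be only part of what the source reports. "The series", "measured", "known", "first", "only" and "open" are said of these compounds alone.

Compound 1 `C/C(=C\Cc1c(O)ccc2c1O[C@H](c1ccc(O)cc1)CC2=O)C/C=C/C(C)(C)O` and compound 2 `COC(C=C(C)C)C/C(C)=C/Cc1c(O)ccc2c1O[C@H](c1ccc(O)cc1)CC2=O` share one core and differ only in their side chains. In a functional assay on KB cells (Homo sapiens) for cytotoxicity, read by MTT assay (on this read-out lower numbers stand for stronger inhibition and higher numbers for weaker inhibition), compound 1 gives only a limit, > 10000 nM. In this assay compound 2 likewise gives only a limit, > 10000 nM. The step that the two limits leave unreadable from compound 1 to compound 2 therefore cannot be read. Compound 3 `CC(C)=CCC/C(C)=C/Cc1c(O)ccc2c1O[C@H](c1ccc(O)cc1)CC2=O` is not yet measured; it differs from compound 2 by hydrogen in place of methoxy on a saturated chain carbon bound to a double-bonded chain carbon and a saturated chain carbon. No measured step bears directly on this change, since the single measured step is unreadable; what stands is the limit of > 10000 nM in this assay, at which 2 of the 2 values shown sit, so neither side-chain variant has shown any measurable potency. The step that the limit leaves unreadable from compound 2 to compound 3 is therefore expected to be small, in no preferred direction, and not beyond the scatter. Compound 3 is estimated at 20000 nM, within 8000 nM to 60000 nM, most probably again reported only as a limit.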

Compound 3, half-maximal inhibitory concentration: > 10000 nM
Compound 3: only a limit was reported; the forecaster's own chance of this, stated with the estimate: 75%; the middle value lies beyond the limit too.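

In this assay, for the compounds shown here, compound 3 also gives only a limit (> 10000 nM) so no step among compound 1, compound 2 and compound 3 can be read. The compounds shown leave open whether any side chain on the shared core gives measurable potency in this assay at all.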